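This account rests on a few compounds, and the source may have more. Where it says the series, first, only, none or still open, it means among the compounds named here.

Three compounds sharing one core were tested in a functional assay on DU-145 cells (Homo sapiens) for inhibition, read by sulforhodamine B assay, with a stated time of 48 h, tested at 10 uM; a higher number here means more inhibition of growth at the concentration tested, a lower number less inhibition of growth. Compound 1 `c1ccc(-c2nc3sc(-c4ccccc4)cn3n2)cc1` gives 15%, the middle number of the three, and both other numbers lie within the usual scatter of it: compound 2 `COc1ccc(-c2nc3sc(-c4ccc(Cl)cc4)cn3n2)cc1` gives 19.3%, and compound 3 `COc1cc(-c2nc3sc(-c4ccccc4)cn3n2)cc(OC)c1OC` gives 9%. No two of these compounds differ in only one place, so no single structural step can be read from their values. Compound 4 `Clc1ccc(-c2cn3nc(-c4ccccc4)nc3s2)cc1` differs from compound 1 in one place: chloro in place of hydrogen on an aromatic carbon. Among the compounds with values here, with no comparable step available among the measured compounds, the expected step of a number 2 percentage points higher from compound 1 to compound 4 (within the scatter) is none beyond the scatter. Compound 4 is therefore expected to give 17%, with a range from 7% to 27%.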

Compound 4, percent growth inhibition at one concentration: 14%
Estimate against measurement, compound 4: 3 percentage points above; measured number inside the range.
By their numbers in this assay, from the lowest: compounds 3, 4, 1 and 2 (each within the scatter of the next, the first and the last beyond it).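

Chloro in place of hydrogen on the aromatic carbon gives a number 1 percentage points lower from compound 1 to compound 4 (within the scatter) in this assay, so this position tolerates the change without a readable shift in growth inhibition. Hydrogen in place of methoxy on an aromatic carbon gives a number 5.3 percentage points lower from compound 2 to compound 4 (within the scatter), so this change cannot be told from repeat variation either. No measurement at hand explains these small steps.

On these data alone, whether an amine or a carboxylic acid at this position would move the number beyond the scatter stays open. So does the effect of chloro on a compound with higher growth inhibition.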